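The compounds below may be only part of what the source reports. "The series", "measured", "known", "first", "only" and "open" are said of these compounds alone.

Measured compounds:
- compound 1 `COc1ccc(CNC(=O)/C(C#N)=C/c2ccc[nH]2)cc1`: in a functional assay on NCI-H460 cells (Homo sapiens) for inhibition, read by MTT assay, with a stated time of 72 h (a lower number here means a stronger inhibitor of growth, a higher number a weaker inhibitor of growth), compound 1 gives > 50000 nM; this value is a limit of the assay.
- compound 2 `COc1ccc(CNC(=O)/C(C#N)=C/c2ccc(Cl)o2)cc1`: compound 2 gives 15000 nM.
- compound 3 `COc1ccc(CNC(=O)/C(C#N)=C/c2ccc(-c3ccccc3)o2)cc1`: compound 3 gives > 100000 nM; this value is a limit of the assay.

Among the compounds with values here, compound 2 is thus the only member of the series with an actual number in this assay; the other two sit at limits (the limit of > 50000 nM in this assay, at which 1 of the 3 values shown sits, and (the limit of > 100000 nM in this assay, at which 1 of the 3 values shown sits)). Both measured steps run through compound 2: an at least 3.3-fold lower number from compound 1 to compound 2 (0.52 log units; beyond the scatter), and an at least 6.6-fold higher number from compound 2 to compound 3 (0.82 log units; beyond the scatter). The group bearing the chloro on the furan is therefore the only variant that produced a readable number.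

Compound 4 `COc1ccc(CNC(=O)/C(C#N)=C/c2ccoc2)cc1` is the next variant. Change: furan-3-yl in place of 5-chlorofuran-2-yl on a double-bonded chain carbon bound to a double-bonded chain carbon. This removes the chloro and shifts the point of attachment on the furan ring. Neither measured step is this exact change, but both steps away from the 5-chlorofuran-2-yl compound gave higher numbers, so a higher number is expected here too, with a real chance that only a limit is returned.

The expected step is a 3.0-fold higher number from compound 2 to compound 4 (0.48 log units; beyond the scatter). Compound 4 is estimated at 45000 nM, with a range of 15000 nM to 150000 nM.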

Compound 4, concentration for 50% growth inhibition: 8000 nM
Estimate against measurement, compound 4: 5.6-fold (0.75 log units) above; measured number below the stated range.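

In this assay, furan-3-yl in place of 5-chlorofuran-2-yl gives a 1.9-fold lower number from compound 2 to compound 4 (0.27 log units; within the scatter), so a readable number at this chain carbon does not depend on the chloro, and compound 2 and compound 4 cannot be ranked against each other. Set against the 1H-pyrrol-2-yl group, the same furan-3-yl gives an at least 6.2-fold lower number from compound 1 to compound 4 (0.79 log units; beyond the scatter), a comparison that rests on a limit, so its true size stays unfixed. Readable numbers now come from two furan variants, yet a furan alone does not secure one, as compound 3 carries a furan and stands at a limit of the assay: the limit of > 100000 nM in this assay, at which 1 of the 4 values shown sits.

The change from compound 2 to compound 4 joins two differences, the loss of the chloro and the shift of attachment on the furan, and the compounds shown do not separate them; plain furan-2-yl would sit directly between the two. Also open, as far as these compounds go, is whether other replacements at this carbon, such as 5-methylfuran-2-yl or thiophen-3-yl, keep a readable number.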